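From chloromethyl to trifluoromethyl on a carbonyl carbon

The source may hold more compounds than are shown below. What is called first, only, known or untested is meant among the compounds shown, and "the series" means these compounds.

Measured so far in a functional assay on K562 cells (Homo sapiens) for antiproliferative activity, read by MTT assay (on this read-out higher numbers stand for weaker inhibition and lower numbers for stronger inhibition), so far:
compound 1 `C=CCOC(=O)N1CCCc2cc(S(=O)(=O)N3CC(c4ccccc4)NC3=O)ccc21` gives 473 nM here
compound 2 `O=C(CCl)N1CCCc2cc(S(=O)(=O)N3CC(c4ccccc4)NC3=O)ccc21` gives 1100 nM here

Of the two measured compounds, compound 2 has the higher number, so it is the weaker inhibitor. Compound 3 (`O=C1NC(c2ccccc2)CN1S(=O)(=O)c1ccc2c(c1)CCCN2C(=O)C(F)(F)F`) keeps the shared core and carries trifluoromethyl in place of chloromethyl on a carbonyl carbon. Within the data shown here, only one measured step bears on this: the modest change at that same carbon (a 2.3-fold higher number from compound 1 to compound 2 (0.37 log units; beyond the scatter)), which lies beyond the scatter. That step replaced allyloxy rather than chloromethyl, so it suggests a possible size but no direction. No shift beyond the scatter is therefore expected in this assay, although a step of similar size remains possible either way. The estimated step is small (a 1.1-fold lower number from compound 2 to compound 3 (0.04 log units; within the scatter)). Compound 3 is expected at 1000 nM (estimated range 350 nM to 3000 nM).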

Compound 3, half-maximal inhibitory concentration: > 20000 nM
Compound 3: only a limit was reported; the forecaster's own chance of this, stated with the estimate: 2%; middle value at least 20-fold (1.30 log units) away from the limit.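

In this assay the reading for compound 3 is a limit of the assay, not a number: the limit of > 20000 nM in this assay, at which 1 of the 3 values shown sits. Even so, putting trifluoromethyl in place of chloromethyl gives an at least 18-fold higher number from compound 2 to compound 3 (1.25 log units; beyond the scatter) and putting it in place of allyloxy gives an at least 42-fold higher number from compound 1 to compound 3 (1.62 log units; beyond the scatter), both much larger than the earlier 2.3-fold higher number from compound 1 to compound 2 (0.37 log units; beyond the scatter). This carbonyl carbon is therefore far more sensitive than the first pair alone could show, and exchanging one group there can cost most of the inhibition.

The values do not explain why trifluoromethyl has this effect. As far as these compounds go, it also remains open whether a methyl group, an amine or a longer chain on the same carbonyl carbon would behave more like chloromethyl or more like trifluoromethyl.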